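The source may report more compounds than this note shows. Statements on the series, on what has been measured and on what is new or still open speak of the compounds shown alone.

Working notes on the series. Within the data shown here, in a functional assay on HeLa cells (Homo sapiens) for antiproliferative activity, read by sulforhodamine B assay, with a stated time of 48 h (on this read-out higher numbers stand for weaker inhibition of growth and lower numbers for stronger inhibition of growth), compound 1 (`CCCCCCc1cn(CCCN2C(=O)COc3ccccc32)nn1`), which carries a hexyl chain, gives 100 nM, the lower of the two numbers so far. Among the measured compounds shown here, compound 2 (`O=C1COc2ccccc2N1CCCn1cc(-c2ccccn2)nn1`) gives 10000 nM, and the only measured step is a 100-fold higher number from compound 1 to compound 2 (2.00 log units; beyond the scatter). Compound 3 (`CCCc1cn(CCCN2C(=O)COc3ccccc32)nn1`) has yet to be measured in this assay. Its change from compound 1 is hydrogen in place of propyl on a saturated chain carbon, three bonds along the chain from an aromatic carbon, so hexyl becomes propyl. For the measured compounds named here, no measured step shortens a chain. The step to compound 2 bears on this only loosely, as it swaps the whole hexyl group, but it shows that this position can move the number strongly. A sizeable rise, smaller than that step, is therefore expected in this assay. The estimated change is a 10-fold higher number from compound 1 to compound 3 (1.00 log units; beyond the scatter). For compound 3 the expected value is 1000 nM, with an estimated range of 200 nM to 5000 nM.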

Compound 3, concentration for 50% growth inhibition: 23200 nM
Beside the measured number, compound 3's estimate is 23-fold (1.37 log units) below it; measured number outside the range, above it.
By their numbers in this assay, from the lowest: compound 1; then compound 2; then compound 3.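

In this assay the shortening of hexyl to propyl gives a 230-fold higher number from compound 1 to compound 3 (2.37 log units; beyond the scatter) and so takes away nearly all of the activity seen with compound 1, with no ring entering at this position. Chain length alone therefore moves the number here as far as the full replacement of hexyl by pyridin-2-yl does. The propyl chain also gives a 2.3-fold higher number from compound 2 to compound 3 (0.37 log units; beyond the scatter) as a modest step, so of the three groups only hexyl gives a low number.

From the compounds shown here alone, it stays open whether the number climbs gradually through pentyl and butyl or changes abruptly, and whether a longer chain such as octyl lowers it further or raises it again. The data shown offer no evidence on why chain length has so large an effect.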